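The source may report more compounds than this note shows. Statements on the series, on what has been measured and on what is new or still open speak of the compounds shown alone.

In an assay on isolated protein for binding affinity to adenosine receptor A3 (Homo sapiens) (on this read-out higher numbers stand for weaker inhibition and lower numbers for stronger inhibition), compound 1 `CNC(=O)[C@]12C[C@@H]1[C@@H](n1cnc3c(NCc4cccc(Cl)c4)nc(C#Cc4ccc(F)c(F)c4)nc31)[C@H](O)[C@@H]2O` gives >= 99 nM, which is a limit of the assay rather than a number. Compound 2 `CNC(=O)[C@]12C[C@@H]1[C@@H](n1cnc3c(NCc4ccc(N=[N+]=[N-])cc4)nc(C#Cc4ccc(F)c(F)c4)nc31)[C@H](O)[C@@H]2O` gives >= 99 nM, again only a limit. The step that the two limits leave unreadable from compound 1 to compound 2 is therefore not readable, as the limit of >= 99 nM in this assay, at which 2 of the 2 values shown sit, shows. Compound 3 `[N-]=[N+]=Nc1ccc(CNc2nc(C#Cc3ccc(F)c(F)c3)nc3c2ncn3[C@H]2[C@H](O)[C@H](O)[C@]3(CO)C[C@H]23)cc1` differs from compound 2 by a group of 10 heavy atoms (7 carbon, 3 oxygen; one three-membered non-aromatic ring of carbon only, one five-membered non-aromatic ring of carbon only) in place of a group of 12 heavy atoms (8 carbon, 1 nitrogen, 3 oxygen; one three-membered non-aromatic ring of carbon only, one five-membered non-aromatic ring of carbon only), on an aromatic nitrogen. Among the measured compounds shown here, no measured step touches this change, and since compound 2 stands only at a limit, neither direction nor size can be taken from the measured pairs. Compound 3 is expected near 1500 nM, within 200 nM to 10000 nM. This estimate means a step that the limit leaves unreadable from compound 2 to compound 3.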

Compound 3, inhibition constant: >= 99 nM
Compound 3: only a limit was reported; the forecaster's own chance of this, stated with the estimate: 70%; the middle value lies beyond the limit too.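

Compound 2 and compound 3 both stand only at a limit, so no step between them can be read: the limit of >= 99 nM in this assay, at which 3 of the 3 values shown sit.

As far as these compounds go, the actual strength of all three compounds stays open, and so does whether the group exchanged on the aromatic nitrogen changes it.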